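The source may hold more compounds than are shown below. What is called first, only, known or untested is meant among the compounds shown, and "the series" means these compounds.

Measured in an ADME assay on HCT-116 cells (Homo sapiens) for cytotoxicity, read by CellTiter-Glo, with a stated time of 72 h; on this read-out lower numbers stand for stronger inhibition and higher numbers for weaker inhibition:
Compound 1 `Cc1cc(C)c(S(=O)(=O)N2CCC(N3CCN(C)CC3)CC2)c(C)c1`: > 5000 nM
Compound 2 `CC1CCN(C2CCN(S(=O)(=O)c3sc(Cl)nc3C3CC3)CC2)CC1`: > 10000 nM

Neither entry is an exact number. For compound 1, the reading of > 5000 nM is a limit of the assay. For compound 2, the reading of > 10000 nM is also a limit. Among the compounds with values here, with only these two limits, and no step between measured compounds, this assay offers no measured guide to how large a single change might be.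

Compound 3 `Cc1cc(C)c(S(=O)(=O)N2CCC(C3OCC(C)CO3)CC2)c(C)c1` keeps the core of compound 1 and alters one group: a group of 7 heavy atoms (5 carbon, 2 oxygen; one six-membered non-aromatic ring with 2 hetero atoms) in place of a group of 7 heavy atoms (5 carbon, 2 nitrogen; one six-membered non-aromatic ring with 2 hetero atoms), on a saturated ring carbon. The two groups match in size and in ring type, and differ in their hetero atoms. No change beyond the usual scatter is expected in this assay, in either direction, and the result may well be another limit. The estimated step, a step that the limit leaves unreadable from compound 1 to compound 3, is correspondingly small. Compound 3 is estimated at 8000 nM, with an expected range from 3000 nM to 25000 nM.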

Compound 3, half-maximal inhibitory concentration: > 5000 nM
Compound 3: only a limit was reported; the forecaster's own chance of this, stated with the estimate: 85%; the middle value is on the limit's open side.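

In this assay, within the data shown here, compound 1 and compound 3 are both reported only as limits, so no step between them can be read. The compounds shown leave open whether replacing the 4-methylpiperazin-1-yl group with the oxygen-containing ring changes the true value at all.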